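The source may hold more compounds than are shown below. What is called first, only, known or untested is meant among the compounds shown, and "the series" means these compounds.

Measured so far in a functional assay on U2OS cells (Homo sapiens) for inhibition, read by CCK-8 assay, with a stated time of 72 h, tested at 1 uM; on this read-out lower numbers stand for less inhibition and higher numbers for more inhibition at the one concentration tested (going by the name of the read-out):
- compound 1, `COc1ccccc1N1C(=O)C(C)SC1c1cccc(C(=O)NCCCCc2ccccc2)c1`: 38%
- compound 2, `COc1ccc(C)cc1N1C(=O)CSC1c1cccc(C(=O)NCCCCc2ccccc2)c1`: 30%
- compound 3, `COc1cccc(OC)c1N1C(=O)CSC1c1cccc(C(=O)NCCCCc2ccccc2)c1`: 41%

Compound 2 gives the lowest of the three numbers in this assay. Compound 1 lies within the usual scatter of compound 2, so the two cannot be ordered; compound 3 stands further off, with a difference beyond the scatter (a number 11 percentage points higher from compound 2 to compound 3 (beyond the scatter)).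

Compound 4, `O=C(NCCCCc1ccccc1)c1cccc(C2SCC(=O)N2c2cccc(F)c2)c1`, is not yet measured. It differs from compound 2 in one place: 3-fluorophenyl in place of 2-methoxy-5-methylphenyl on an amide-type nitrogen in a ring.

For the measured compounds named here, only one measured step bears on this position, the exchange of the group on the ring nitrogen from compound 2 to compound 3, which gave a number 11 percentage points higher from compound 2 to compound 3 (beyond the scatter). Going by the values given here, that step adds a second methoxy rather than removing the methoxy and methyl altogether, so it is a loose guide; there is no measured step in which a methoxy is taken away. Three compounds are too few to claim a pattern. The expectation is therefore a step of no clear direction, most likely within the scatter (a number 2 percentage points higher from compound 2 to compound 4 (within the scatter)). Compound 4 is expected to give about 32% in this assay, estimated between 18% and 48%.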

Compound 4, a percentage reported as inhibition, at one concentration (the size of the read-out at that concentration, not a potency): 39%
Beside the measured number, compound 4's estimate is 7 percentage points below it; measured number inside the range.
By their numbers in this assay, from the lowest: compounds 2, 1, 4 and 3 (each within the scatter of the next, the first and the last beyond it).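

In this assay, a methoxy on the group at the ring nitrogen is not needed to keep the number in this range: the change to 3-fluorophenyl gives a number 9 percentage points higher from compound 2 to compound 4 (within the scatter), and against the dimethoxy compound it gives a number 2 percentage points lower from compound 3 to compound 4 (within the scatter). Neither step leaves the scatter, so compound 4 cannot be ordered against compound 2 or compound 3, although a number 11 percentage points higher from compound 2 to compound 3 (beyond the scatter) stands apart. No measurement is available that could account for these numbers.

Open, going by these compounds, is whether a group of another kind on the ring nitrogen, such as a pyridine ring, a benzyl group or a phenyl ring carrying an amine or a carboxylic acid, would move the number beyond the scatter. Also open, on these data alone, is whether the compounds would separate at other concentrations, as a single concentration gives no potency.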